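This account rests on a few compounds, and the source may have more. Where it says the series, first, only, none or still open, it means among the compounds named here.

Measured compounds:
compound 1, `COCCNC(=O)Cn1sc2ccccc2c1=O`, 92%
compound 2, `Cc1ccc(-c2csc(-n3sc4ccccc4c3=O)n2)cc1`, 70%

In an assay on isolated protein for inhibition of histone acetyltransferase KAT2B (Homo sapiens), read by fluorescence, with a stated time of 10 min, tested at 50 uM (on this read-out higher numbers stand for more inhibition at the one concentration tested (going by the name of the read-out) and lower numbers for less inhibition), compound 1 gives 92%, the higher of the two numbers shown. Compound 2 gives 70%, a gap to compound 1 that lies beyond the usual scatter. Among the compounds with values here, no measured pair in this set differs in only one place, so no single-step comparison of the kind that compound 1 and compound 3 form has been observed yet.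

Compound 3, `O=C(Cn1sc2ccccc2c1=O)NCc1ccccn1`, differs from compound 1 as follows: pyridin-2-yl in place of methoxymethyl on a saturated chain carbon bound to an amide-type nitrogen. In this assay a small downward step is expected for this change, of a size that stays within the scatter, since compound 1 already stands close to the top of the read-out with 92%. The expected step is a number 7 percentage points lower from compound 1 to compound 3 (within the scatter). Compound 3 is estimated at 85%, with a range from 65% to 98%.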

Compound 3, a percentage reported as inhibition, at one concentration (the size of the read-out at that concentration, not a potency): 91%
Compound 3: middle estimate off by 6 percentage points, on the low side; measured number inside the range.
By their numbers in this assay, from the lowest: compound 2; then compounds 3 and 1 (each within the scatter of the next).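

In this assay, putting pyridin-2-yl in place of methoxymethyl on a saturated chain carbon bound to an amide-type nitrogen gives a number 1 percentage points lower from compound 1 to compound 3 (within the scatter), so this position accepts a six-membered aromatic ring in place of an open chain with no change that can be told from the scatter. Both numbers lie close to the top of the read-out and come from one concentration, so they show that inhibition is kept at this position but do not separate the two groups in potency. No measurement at hand speaks to why the two groups read alike.

Going by these compounds, it remains open whether phenyl, with no ring nitrogen, would read like pyridin-2-yl at this place. Also open, on these data alone, is whether a carboxylic acid, an amine or a longer chain here would keep the number near the top.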